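The source may report more compounds than this note shows. Statements on the series, on what has been measured and on what is new or still open speak of the compounds shown alone.

Measured compounds:
compound 1, `C=CCc1c(SC)nc2nc(C(=O)c3ccccc3)cn2c1C`, gives 5 mg/kg in a functional assay on the whole organism with Rattus norvegicus as the target; a lower number here means that less compound is needed, a higher number that more compound is needed for the effect
compound 2, `COc1nc2nc(C(=O)c3ccccc3)cn2c(C)c1CC1CC1`, gives 10 mg/kg in this assay

Going by the values given here, compound 2 stands beside compound 1 as one of only two measured compounds, and its value in this assay lies within the usual scatter of the value of compound 1, so the two cannot be set apart from each other on these numbers. Compound 3, `CCCc1c(OC)nc2nc(C(=O)c3ccccc3)cn2c1C`, has not yet been tested in this assay. It differs from compound 2 in a single place: ethyl in place of cyclopropyl on a saturated chain carbon bound to an aromatic carbon. Among the compounds with values here, no pair of measured compounds shows this kind of change, so nothing in the available data tells how large a step it brings. With a change confined to a small saturated group and no comparison to lean on, the expected step from compound 2 to compound 3 in this assay is no change at the digits printed from compound 2 to compound 3 (within the scatter), that is, none beyond the scatter in either direction. Compound 3 is therefore estimated to give 10 mg/kg in this assay, with a range from 3 mg/kg to 30 mg/kg.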

Compound 3, minimum effective dose: 5 mg/kg
Compound 3: the middle estimate sits 2.0-fold (0.30 log units) above what was measured, and the stated range covers the measured number.
By their numbers in this assay, from the lowest: compounds 1, 3 and 2 (each within the scatter of the next).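

In this assay, the step from cyclopropyl to ethyl on a saturated chain carbon bound to an aromatic carbon, which can also be read as cyclopropylmethyl to propyl, gives a 2.0-fold lower number from compound 2 to compound 3 (0.30 log units; within the scatter). Going by these compounds alone, this is the first pair that differs in one place only, and it shows that at this position the three-membered ring can give way to an open chain without a step beyond the scatter, so the ring is not needed here for the dose to stay in the same range. No measured property of either group bears on this result, so the numbers give no explanation for it.

Going by these compounds, a single pair says little about how much this position tolerates, and it remains open how a longer chain such as butyl, a benzyl group, or a chain carrying an amine or a carboxylic acid would fare here. On these data alone, it is also open whether the swap of cyclopropylmethyl for propyl would read the same on a core that carries a group other than methoxy.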